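Swapping 2-Hydroxyphenyl for 3-Methylphenyl

The source may hold more compounds than are shown below. What is called first, only, known or untested is meant among the compounds shown, and "the series" means these compounds.

Of the compounds shown here, three that share one core have been tested in a functional assay on LoVo cells (Homo sapiens) for inhibition, read by MTT assay, with a stated time of 24 h; a lower number here means a stronger inhibitor, a higher number a weaker inhibitor. In this test, compound 1 `CC1(C)[C@H]2CC[C@]1(C)N(Cc1cn(-c3ccccc3F)nn1)C(=O)C2` gives 40 nM and compound 2 `CC1(C)[C@H]2CC[C@]1(C)N(Cc1cn(-c3cccc(Cl)c3)nn1)C(=O)C2` gives 70 nM. Between these two lies a 1.8-fold higher number from compound 1 to compound 2 (0.24 log units; within the scatter), so they cannot be told apart. Compound 3 `CC1(C)[C@H]2CC[C@]1(C)N(Cc1cn(-c3ccccc3O)nn1)C(=O)C2` gives 540 nM, the highest number of the three and so the weakest inhibitor here. The gaps to it are clear: a 14-fold higher number from compound 1 to compound 3 (1.13 log units; beyond the scatter), and a 7.7-fold higher number from compound 2 to compound 3 (0.89 log units; beyond the scatter).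

Compound 4 `Cc1cccc(-n2cc(CN3C(=O)C[C@@H]4CC[C@@]3(C)C4(C)C)nn2)c1` keeps the shared core and changes one group: 3-methylphenyl in place of 2-hydroxyphenyl on an aromatic nitrogen. The 3-methylphenyl group sits on the same aromatic nitrogen of the five-membered aromatic ring that held the 2-hydroxyphenyl group.

Compound 4 has no hydroxy group, and neither do the two tested compounds with the lower numbers, compound 1 at 40 nM and compound 2 at 70 nM. The two steps into compound 3 therefore bear most directly on this change, taken in reverse. Among the compounds with values here, no tested compound carries a methyl group, so the size of the step remains uncertain. A drop of similar size to the step from compound 2 seems the best guess, and the expected change is a 5.4-fold lower number from compound 3 to compound 4 (0.73 log units; beyond the scatter). The estimated value for compound 4 is 100 nM, with an expected range from 35 nM to 300 nM.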

Compound 4, half-maximal inhibitory concentration: 50 nM
Compound 4: middle estimate off by 2.0-fold (0.30 log units), on the high side; measured number inside the range.
By their numbers in this assay, from the lowest: compounds 1, 4 and 2 (each within the scatter of the next); then compound 3.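

Moving from the 2-hydroxyphenyl group to the 3-methylphenyl group gives an 11-fold lower number from compound 3 to compound 4 (1.03 log units; beyond the scatter) in this assay, and this change removes the hydrogen-bond donor and acceptor counted on the leaving group, so compound 3, the only one of the four with a hydroxy group, now stands apart from three compounds rather than two. Compound 4 also shows that this position accepts more than halogen-bearing phenyl groups without a clear shift: methyl in place of chloro gives a 1.4-fold lower number from compound 2 to compound 4 (0.15 log units; within the scatter) and the comparison with the 2-fluorophenyl group gives a 1.3-fold higher number from compound 1 to compound 4 (0.10 log units; within the scatter), both within the scatter, so compounds 1, 2 and 4 cannot be told apart. Nothing measured here explains why compound 3 gives the higher number.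

The step into compound 4 changes both the group and its place on the phenyl ring, so a 3-hydroxyphenyl or 2-methylphenyl compound would be needed to separate those two changes. Going by these compounds, whether the high number follows the hydroxy group alone also stays open, as does how a methoxy group, an amine or a carboxylic acid would fare on this phenyl ring.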